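From Isopropyl to Pyridinylmethyl on the Ring Nitrogen

The source may hold more compounds than are shown below. What is called first, only, known or untested is meant among the compounds shown, and "the series" means these compounds.

Of the compounds shown here, two sharing one core have been measured in a functional assay on CCRF-CEM cells for antagonist activity at C-X-C chemokine receptor type 4 (Homo sapiens), read by calcium flux, with stated times of 25 min and 90 s; on this read-out lower numbers stand for stronger inhibition and higher numbers for weaker inhibition. Compound 1 `CN(C[C@H]1Cc2c(cccc2N2CCN(C3CC3)CC2)CN1)[C@H]1CCCc2cccnc21` carries a cyclopropyl group on an amine nitrogen in a ring, and in this assay compound 1 gives 23.5 nM. Compound 2 `CC(C)N1CCN(c2cccc3c2C[C@H](CN(C)[C@H]2CCCc4cccnc42)NC3)CC1` carries an isopropyl group at the same place, and in this assay compound 2 gives 16.9 nM. For the measured compounds named here, the only step measured so far, a 1.4-fold lower number from compound 1 to compound 2 (0.14 log units; within the scatter), leaves compound 2 with the lower of the two numbers, yet the gap lies within the scatter, so no order between the two can be read.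

Compound 3 `CN(C[C@H]1Cc2c(cccc2N2CCN(Cc3ccccn3)CC2)CN1)[C@H]1CCCc2cccnc21` has not been measured. It differs from compound 2 in one place: (pyridin-2-yl)methyl in place of isopropyl on an amine nitrogen in a ring. The known step from cyclopropyl to isopropyl bears on this change only loosely, since the entering group is larger than either group measured at this place, and that step was itself within the scatter. Nothing measured shows what a group of this kind does here. The step from compound 2 to compound 3 is therefore expected to be a 1.5-fold higher number from compound 2 to compound 3 (0.17 log units; within the scatter), with a wide range. Compound 3 is estimated at 25 nM in this assay, from 8 nM to 80 nM.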

Compound 3, half-maximal inhibitory concentration: 4.47 nM
For compound 3 the middle estimate is 5.6-fold (0.75 log units) above the measured one; the whole stated range lies above it.
By their numbers in this assay, from the lowest: compound 3; then compounds 2 and 1 (each within the scatter of the next).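

In this assay, the step from isopropyl to (pyridin-2-yl)methyl is a 3.8-fold lower number from compound 2 to compound 3 (0.58 log units; beyond the scatter) and so gives this position its first change beyond the scatter, whereas the earlier exchange of cyclopropyl for isopropyl stayed within it. The same group, set against cyclopropyl, gives a 5.3-fold lower number from compound 1 to compound 3 (0.72 log units; beyond the scatter) and thus a second modest step in the same direction, showing that the amine nitrogen in the ring tolerates a group of 7 heavy atoms with a six-membered aromatic ring and that the number falls rather than rises when it enters, compared with the 3 heavy atoms of isopropyl. No measurement offered here accounts for this gain.

The three compounds do not separate the contribution of the aromatic ring from that of its ring nitrogen, since a benzyl group, which would carry the same ring with carbon alone, and the isomeric (pyridin-3-yl)methyl group are not among them. They also leave open how the number responds to a longer chain between the aromatic ring and the amine nitrogen, or to a second nitrogen in that ring, as in a pyrimidine.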